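Trimming the acetyl from compound 1: an expectation for compound 4

This account rests on a few compounds, and the source may have more. Where it says the series, first, only, none or still open, it means among the compounds named here.

Measured so far in an assay on isolated protein for inhibition of Tryptophan 2,3-dioxygenase (Homo sapiens); a higher number here means a weaker inhibitor, a lower number a stronger inhibitor:
compound 1 `CC(=O)CC(=O)/C=C1\C(=O)Nc2ccc(Cl)cc21`: 39900 nM
compound 2 `O=C1Nc2ccccc2/C1=N/Nc1ccc(Cl)cc1`: 53400 nM
compound 3 `O=C1Nc2ccccc2/C1=N/Nc1ccccc1C(F)(F)F`: 38300 nM

Compound 1 gives the second highest of the three numbers; its gaps to compound 3 and to compound 2 both lie within the scatter, so the three compounds are not separated in this assay. The unmeasured compound 4 `CC(=O)/C=C1\C(=O)Nc2ccc(Cl)cc21` differs from compound 1 in one place: hydrogen in place of acetyl on a saturated chain carbon bound to a carbonyl carbon. For the measured compounds named here, no step between measured compounds of this kind is available, and compounds 2 and 3 carry nothing of this chain, so they do not inform the change. A small step is expected, at most a modest weakening and possibly nothing beyond the scatter, so a 1.2-fold higher number from compound 1 to compound 4 (0.08 log units; within the scatter) is the expected step. For compound 4 the estimate in this assay is 48000 nM, with a range from 20000 nM to 115000 nM.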

Compound 4, half-maximal inhibitory concentration: 54700 nM
Compound 4: middle estimate off by 1.1-fold (0.06 log units), on the low side; the measured number falls inside the stated range.
By their numbers in this assay, from the lowest: compounds 3, 1, 2 and 4 (each within the scatter of the next).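

In this assay, the change gives a 1.4-fold higher number from compound 1 to compound 4 (0.14 log units; within the scatter) and stays within the scatter, so compound 4 is not separated from compound 1. At this saturated chain carbon bound to a carbonyl carbon, hydrogen in place of acetyl therefore has no readable effect, and the shorter chain keeps the number at the level of compound 1. No supporting data bear on why this change leaves the number unresolved.

Open, on these data alone, is whether an amine, a carboxylic acid or a longer chain at this place would give a step beyond the scatter.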